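A few compounds are considered here, and "the series" means these few. Any claim that something is new, unique, unknown or untested is made for them only; others in the source may bear on it.

Of the compounds shown here, three sharing one core have been tested in a functional assay on the whole organism (strain Kunming) with Mus musculus as the target, in the formalin test, with a stated time of 0.5 h; on this read-out higher numbers stand for an effect only at larger amounts of compound and lower numbers for an effect already at smaller amounts. Compound 1 `COc1cc(OC)c(OC)cc1/C=C/COC(=O)/C=C/c1ccccc1C(F)(F)F` gives 291 umol/kg, and compound 2 `COc1cc(OC)c(OC)cc1/C=C/COC(=O)/C=C/c1cccc(Br)c1` gives 260 umol/kg. Compound 3 `COc1cccc(/C=C/C(=O)OC/C=C/c2cc(OC)c(OC)cc2OC)c1` gives > 260 umol/kg, which is a limit of the assay and not a number. Compound 3 therefore has no exact place on the scale, and the limit of > 260 umol/kg in this assay, at which 1 of the 3 values shown sits, is all that can be said of it.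

Compound 4 `COc1ccc(/C=C/C(=O)OC/C=C/c2cc(OC)c(OC)cc2OC)cc1` differs from compound 3 in a single group: 4-methoxyphenyl in place of 3-methoxyphenyl on a double-bonded chain carbon bound to a double-bonded chain carbon. The two have the same atoms, joined differently.

Within the data shown here, only one measured step has a readable size, a 1.1-fold lower number from compound 1 to compound 2 (0.05 log units; within the scatter). It swaps one substituted phenyl group for another at the same place on the chain. From the compounds shown here alone, the other two, a step that the limit leaves unreadable from compound 1 to compound 3 and a number no lower from compound 2 to compound 3 (the limit leaves the size open), stay open because of the limit of > 260 umol/kg in this assay, at which 1 of the 3 values shown sits. Among the measured compounds shown here, no measured compound carries the 4-methoxyphenyl group, so the guidance is indirect. For the measured compounds named here, the one readable step suggests that no change beyond the scatter should be expected in this assay, and no direction is favoured. The step expected is a number no higher from compound 3 to compound 4 (the limit leaves the size open). For compound 4 the estimate is 260 umol/kg, with an expected range from 130 umol/kg to 400 umol/kg.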

Compound 4, dose for half-maximal effect: 317 umol/kg
Compound 4: the middle estimate sits 1.2-fold (0.09 log units) below what was measured, and the stated range covers the measured number.
By their numbers in this assay, from the lowest: compounds 2, 1 and 4 (each within the scatter of the next).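

In this assay, among these compounds, compound 4 gives 317 umol/kg, the first exact number for a methoxy-bearing phenyl group on a double-bonded chain carbon bound to a double-bonded chain carbon. The comparisons show a 1.2-fold higher number from compound 2 to compound 4 (0.09 log units; within the scatter) and a 1.1-fold higher number from compound 1 to compound 4 (0.04 log units; within the scatter), so the 4-methoxyphenyl, 3-bromophenyl and 2-(trifluoromethyl)phenyl groups cannot be told apart at this place in this test. Compound 3 has only a limit, so the steps that involve it cannot be read, and the effect of exchanging 3-methoxyphenyl for 4-methoxyphenyl stays unknown because of this: the limit of > 260 umol/kg in this assay, at which 1 of the 4 values shown sits.

From the compounds shown here alone, all the exact values so far come from phenyl groups carrying one neutral substituent, so it remains open whether a phenyl group bearing an amine or a carboxylic acid at this place would shift the number beyond the scatter. The rest of the shared core is also the same throughout, which leaves open what an amide in place of the ester would do.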